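Adding a Bromo Group: Two Parallel Comparisons

The source may hold more compounds than are shown below. What is called first, only, known or untested is meant among the compounds shown, and "the series" means these compounds.

Compound 1 `O=C1N=C(N2N=C(c3ccccc3)CC2c2ccccc2O)S/C1=C1/C(=O)Nc2ccccc21` and compound 2 `O=C1N=C(N2N=C(c3ccccc3)CC2c2ccccc2O)S/C1=C1/C(=O)Nc2ccc(Br)cc21` share a core and differ in one place: bromo in place of hydrogen on an aromatic carbon. In a functional assay on cells (Cancer cell lines, Homo sapiens) for cytotoxicity, read by sulforhodamine B assay, with a stated time of 48 h (a higher number here means a weaker inhibitor of growth, a lower number a stronger inhibitor of growth), compound 1 gives 2070 nM, while compound 2 gives 230 nM, so the change brought a 9.0-fold lower number from compound 1 to compound 2 (0.95 log units; beyond the scatter). Compound 3 `COc1ccc(C2CC(c3ccc4ccccc4c3)=NN2C2=NC(=O)/C(=C3\C(=O)Nc4ccccc43)S2)cc1` rests on a different core; how this core differs from the core of compound 1 is not broken down here. In this assay compound 3 gives 870 nM. Compound 4 `COc1ccc(C2CC(c3ccc4ccccc4c3)=NN2C2=NC(=O)/C(=C3\C(=O)Nc4ccc(Br)cc43)S2)cc1` has not yet been measured. Going by the values given here, it differs from compound 3 by bromo in place of hydrogen on an aromatic carbon, the same change as the one between compound 1 and compound 2. Because the earlier step was a 9.0-fold lower number from compound 1 to compound 2 (0.95 log units; beyond the scatter), a gain in the same direction is expected for compound 4, though the different core makes its size less certain. For compound 4 the expected step is a 4.4-fold lower number from compound 3 to compound 4 (0.64 log units; beyond the scatter). Compound 4 is therefore estimated at 200 nM, with a likely range from 70 nM to 600 nM.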

Compound 4, concentration for 50% growth inhibition: 64 nM
For compound 4 the middle estimate is 3.1-fold (0.49 log units) above the measured one; the whole stated range lies above it.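

In this assay, bromo in place of hydrogen again lowers the number, with a 14-fold lower number from compound 3 to compound 4 (1.13 log units; beyond the scatter). Set beside the earlier step on the other core, the two steps agree as closely as repeated measurements allow: the same change on two cores in this assay, a 9.0-fold lower number (0.95 log units; beyond the scatter) from compound 1 to compound 2 and a 14-fold lower number (1.13 log units; beyond the scatter) from compound 3 to compound 4, 1.5-fold (0.18 log units) apart, within the scatter of two such steps. In these two pairs, then, the change carried from one core to the other in the same direction and at a similar size, but two pairs cannot show that it would do so on any further core, and a cell read-out alone does not show how the gain arises.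

The compounds shown leave open whether a chloro or a methyl group on the same aromatic carbon would bring a similar gain. They also leave open what bromo would do on another carbon of that ring.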